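Ethyl for hydrogen on a cyanoguanidine nitrogen: expected gain

The compounds below may be only part of what the source reports. "The series", "measured", "known", "first", "only" and "open" are said of these compounds alone.

Measured compounds:
- compound 1, `N#C/N=C(/NCCCCc1c[nH]cn1)NCCCC1CCCCC1`, < 5
- compound 2, `N#C/N=C(\N)NCCCCc1c[nH]cn1`, < 5

Compound 2 has only a limit in an in vitro functional assay on Sf9 cells for antagonist activity at histamine H2 receptor (Homo sapiens) (a higher number here means a more potent compound, by a factor of ten per unit of this negative logarithm, a lower number a less potent compound), given as < 5. Going by the values given here, the same holds across the set, since (the limit of < 5 in this assay, at which 2 of the 2 values shown sit), so no measured number stands anywhere yet and no step between two numbers can be read off. Compound 3, `CCN/C(=N\C#N)NCCCCc1c[nH]cn1`, has not been measured. It differs from compound 2 by ethyl in place of hydrogen on an amine nitrogen. Without any measured step, the size of this change in this assay is guessed only from the fact that compound 2 sits at the limit: a rise is expected, but it might still leave the result as a limit. Compound 3 is therefore expected to reach roughly 5.3, within 4.5 to 6.1, a move of a number at least 0.30 log units higher from compound 2 to compound 3 (that floor lies within the scatter) that is estimated, not measured.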

Compound 3, negative logarithm of the antagonist equilibrium constant: < 5
Compound 3: no number, only a limit; the forecaster's own chance of this, stated with the estimate: 40%; middle value at least 0.30 log units from the limit.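

No step linking compound 3 with compound 2 or compound 1 can be read, because each result is only a limit and not a number: the limit of < 5 in this assay, at which 3 of the 3 values shown sit.

From the compounds shown here alone, what ethyl in place of hydrogen on an amine nitrogen does in this assay therefore remains open.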